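The compounds below may be only part of what the source reports. "The series", "measured", "known", "first", "only" and "open" are said of these compounds alone.

Compound 1 `O=C1/C(=C/c2ccccc2Br)NS(=O)(=O)c2ccccc21`, compound 2 `O=C1/C(=C/c2ccc(Cl)cc2)NS(=O)(=O)c2ccccc21`, compound 3 `Cc1ccccc1/C=C1\NS(=O)(=O)c2ccccc2C1=O`.

In an assay for inhibition of alkaline phosphatase, tissue-nonspecific isozyme (Homo sapiens), read by spectrophotometry, with stated times of 10 min and 20 min (a higher number here means a weaker inhibitor, a lower number a stronger inhibitor), compound 1 gives only a limit of the assay, > 200000 nM. In this assay compound 2 gives 250 nM. Compound 3 gives 2360 nM, the higher of the two numbers; its nearest neighbour is compound 2, with a 9.4-fold higher number from compound 2 to compound 3 (0.97 log units; beyond the scatter). The remaining value is a limit (the limit of > 200000 nM in this assay, at which 1 of the 3 values shown sits).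

Compound 4 `O=C1/C(=C/c2cccc(O)c2)NS(=O)(=O)c2ccccc21` differs from compound 3 by 3-hydroxyphenyl in place of 2-methylphenyl on a double-bonded chain carbon bound to a double-bonded ring carbon. Two measured steps change the same phenyl group: an at least 84-fold lower number from compound 1 to compound 3 (1.92 log units; beyond the scatter) and a 9.4-fold higher number from compound 2 to compound 3 (0.97 log units; beyond the scatter), one large, one modest. A change of this kind is therefore expected to shift the number, here modestly downward: a 2.4-fold lower number from compound 3 to compound 4 (0.37 log units; beyond the scatter). Compound 4 is expected to give about 1000 nM, between 200 nM and 5000 nM.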

Compound 4, half-maximal inhibitory concentration: 3570 nM
For compound 4 the middle estimate is 3.6-fold (0.55 log units) below the measured one; measured number inside the range.
By their numbers in this assay, from the lowest: compound 2; then compounds 3 and 4 (each within the scatter of the next). At a limit, above all of these: compound 1.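

In this assay, 3-hydroxyphenyl in place of 2-methylphenyl gives a 1.5-fold higher number from compound 3 to compound 4 (0.18 log units; within the scatter), so these two groups cannot be told apart at this place, although only 3-hydroxyphenyl has a hydrogen-bond donor and acceptor. In place of 4-chlorophenyl, the same group gives a 14-fold higher number from compound 2 to compound 4 (1.15 log units; beyond the scatter), leaving compound 2 ahead of compound 4. In place of 2-bromophenyl, it gives an at least 56-fold lower number from compound 1 to compound 4 (1.74 log units; beyond the scatter), a step read from a limit: the limit of > 200000 nM in this assay, at which 1 of the 4 values shown sits.

From the compounds shown here alone, how an amine or a carboxylic acid would compare at this place remains open. So does whether the hydroxy group itself or its place on the ring decides the result of compound 4.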